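A few compounds are considered here, and "the series" means these few. Any claim that something is new, unique, unknown or untested is made for them only; others in the source may bear on it.

Compound 1 `Cc1csc(NC(=O)c2cc(C(C)(C)C)nn2Cc2ccccc2)n1` carries a 4-methyl-1,3-thiazol-2-yl group on its amide nitrogen. In a physicochemical assay for solubility, read by nephelometry, measured as kinetic solubility, at pH 6.5 (on this read-out lower numbers stand for lower solubility and higher numbers for higher solubility), compound 1 gives < 1.6 ug/mL, which is a limit of the assay rather than a number. This is the limit of < 1.6 ug/mL in this assay, at which 1 of the 2 values shown sits. Compound 2 `COc1ccc(C(=O)Nc2nc(CN)cs2)cc1` is a separate molecule, and in this assay compound 2 gives 25 ug/mL. Compound 3 `CC(C)(C)c1cc(C(=O)Nc2ccncc2)n(Cc2ccccc2)n1` has not yet been measured; it differs from compound 1 in one place: pyridin-4-yl in place of 4-methyl-1,3-thiazol-2-yl on an amide-type nitrogen. Among the compounds with values here, no measured step exists between compounds that differ only in this way, so the expectation rests on the change alone: an upward step, beyond the scatter, is expected, an at least 3.1-fold higher number from compound 1 to compound 3 (0.49 log units; beyond the scatter). Compound 3 is therefore estimated at 5 ug/mL, between 1.6 ug/mL and 20 ug/mL.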

Compound 3, solubility: 6.3 ug/mL
For compound 3 the middle estimate is 1.3-fold (0.10 log units) below the measured one, within the range that was stated.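

Within the data shown here, on the amide-type nitrogen of the shared core, pyridin-4-yl in place of 4-methyl-1,3-thiazol-2-yl gives the first readable step at this position in this assay: an at least 3.9-fold higher number from compound 1 to compound 3 (0.59 log units; beyond the scatter). With pyridin-4-yl, this core now reads as a number rather than a limit. Compound 1 gives < 1.6 ug/mL, which is a limit, so the full size of the step stays open: the limit of < 1.6 ug/mL in this assay, at which 1 of the 3 values shown sits.

Going by these compounds, whether pyridin-3-yl or a plain phenyl ring on this nitrogen would read the same remains open. So does whether the step would hold on a different core.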